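This account rests on a few compounds, and the source may have more. Where it says the series, first, only, none or still open, it means among the compounds named here.

Measured in a functional assay on A549 cells (Homo sapiens) for cytotoxicity, read by MTT assay, with a stated time of 72 h; on this read-out lower numbers stand for stronger inhibition and higher numbers for weaker inhibition:
- compound 1 `CCN1C/C(=C\c2ccc(OC)c(OC)c2)C(=O)/C(=C/c2ccc(OC)c(OC)c2)C1`: 3600 nM
- compound 2 `COc1cc(/C=C2\CN(C(=O)CCC(=O)O)C/C(=C\c3cc(OC)c(OC)c(OC)c3)C2=O)cc(OC)c1OC`: 17900 nM

Compound 2 holds the higher of these two numbers. In this assay, compound 2 gives 17900 nM and compound 1 gives 3600 nM, a gap that lies beyond the usual scatter of repeated measurements.

Compound 3 `COc1cc(/C=C2\CN(C(=O)c3ccccc3F)C/C(=C\c3cc(OC)c(OC)c(OC)c3)C2=O)cc(OC)c1OC` has not yet been measured. It keeps the core of compound 2 and differs from it in one place: 2-fluorophenyl in place of 2-carboxyethyl on a carbonyl carbon. The exchange is 2-fluorophenyl in place of 2-carboxyethyl on a carbonyl carbon whose other neighbour is an amide-type nitrogen in a ring.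

For the measured compounds named here, no two measured compounds differ in only one place, so the data offer no direct precedent for this exchange. Going by the values given here, the only guide is that compound 2, at 17900 nM, has the higher number of the pair, which leaves room for a fall. A move to a lower number in this assay, beyond the scatter, is therefore expected, though this is a judgement with little support. The expected size of the move is a 7.2-fold lower number from compound 2 to compound 3 (0.85 log units; beyond the scatter). For compound 3 the estimated value is 2500 nM, with an expected range from 500 nM to 10000 nM.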

Compound 3, half-maximal inhibitory concentration: 700 nM
For compound 3 the middle estimate is 3.6-fold (0.55 log units) above the measured one; the range from low to high includes it.
By their numbers in this assay, from the lowest: compound 3; then compound 1; then compound 2.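

In this assay, the group on the carbonyl carbon whose other neighbour is an amide-type nitrogen in a ring changes from 2-carboxyethyl to 2-fluorophenyl, and this gives a 26-fold lower number from compound 2 to compound 3 (1.41 log units; beyond the scatter), so the number in this assay depends strongly on the group held at this place on the shared core. For the compounds shown here, this is the first comparison that isolates a single place, which the earlier pair of compounds could not do, and it ties a large step to this exchange alone: a ringless chain with one hydrogen-bond donor and one hydrogen-bond acceptor gives way to a six-membered aromatic ring of carbon only, with neither. No measurement available here accounts for the step, so the result records its size and not its origin.

The compounds shown leave open whether the step follows from the arrival of the aromatic ring, the presence of the fluorine or the departure of the 2-carboxyethyl chain. A plain phenyl, a chlorophenyl or the methyl ester of the same chain on this carbonyl carbon would each separate these parts of the exchange.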